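Bombesin receptor 3 agonists: tetrazolyl to fluoropyridinyl swap

The source may hold more compounds than are shown below. What is called first, only, known or untested is meant among the compounds shown, and "the series" means these compounds.

In a functional assay on HEK293 cells for agonist activity at Bombesin receptor subtype-3 (Mus musculus), read by luminescence and calcium flux, with a stated time of 10 min (on this read-out lower numbers stand for an effect already at smaller amounts and higher numbers for an effect only at larger amounts of compound), compound 1 `CCC(C)(C)Cc1c[nH]c(CCc2ccc(-n3cccn3)cc2)n1` gives 9 nM, compound 2 `CCC(C)(C)Cc1c[nH]c(CCc2ccc(-n3ncnn3)cc2)n1` gives 25 nM and compound 3 `CCC(C)(C)Cc1c[nH]c(CCc2ccc(-c3cccc(C#N)n3)cc2)n1` gives 26 nM. Compound 2 stands second highest of the three; its nearest neighbour lies within the scatter, while the furthest step is beyond it: a 2.8-fold higher number from compound 1 to compound 2 (0.44 log units; beyond the scatter). Compound 4 `CCC(C)(C)Cc1c[nH]c(CCc2ccc(-c3ccc(F)cn3)cc2)n1` carries the change (5-fluoropyridin-2-yl in place of 2H-tetrazol-2-yl on an aromatic carbon). Going by the values given here, the steps that bear on this are a 2.9-fold higher number from compound 1 to compound 3 (0.46 log units; beyond the scatter) and a 1.0-fold higher number from compound 2 to compound 3 (0.02 log units; within the scatter), as compound 3 also carries a six-membered aromatic ring with one hetero atom on that aromatic carbon. Exchanging the tetrazolyl for such a ring gave no step beyond the scatter, so the same is expected here: a 1.3-fold lower number from compound 2 to compound 4 (0.10 log units; within the scatter). For compound 4 in this assay the estimate is 20 nM, with a range from 8 nM to 50 nM.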

Compound 4, half-maximal effective concentration: 16 nM
Compound 4: middle estimate off by 1.3-fold (0.10 log units), on the high side; the range from low to high includes it.
By their numbers in this assay, from the lowest: compounds 1, 4, 2 and 3 (each within the scatter of the next, the first and the last beyond it).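

In this assay, 5-fluoropyridin-2-yl on this aromatic carbon reads level with both earlier replacements: a 1.6-fold lower number from compound 2 to compound 4 (0.19 log units; within the scatter) and a 1.6-fold lower number from compound 3 to compound 4 (0.21 log units; within the scatter). Going by these compounds alone, of the three groups set in place of 1H-pyrazol-1-yl, only this one gives a step within the scatter: a 1.8-fold higher number from compound 1 to compound 4 (0.25 log units; within the scatter). No measured evidence accounts for these steps.

The compounds shown leave open what the fluorine itself contributes, as compound 3 and compound 4 differ in both the substituent and its place on the pyridine. From the compounds shown here alone, how a plain pyridin-2-yl, or a pyridine carrying a methoxy group or an amine, would read here also remains open.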